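The source may hold more compounds than are shown below. What is called first, only, known or untested is meant among the compounds shown, and "the series" means these compounds.

Measured compounds:
compound 1, `CC(=O)OC/C(=C\c1ccccc1F)C(=O)c1ccccc1` — 22000 nM in a functional assay on HeLa cells (Homo sapiens) for inhibition, read by sulforhodamine B assay, with a stated time of 48 h; a lower number here means a stronger inhibitor of growth, a higher number a weaker inhibitor of growth
compound 2, `CC(=O)OC/C(=C\c1ccccc1[N+](=O)[O-])C(=O)c1ccccc1` — 25000 nM in this assay

Compound 2 gives the highest of the two numbers in this assay, and compound 1 lies nearest to it; the step of a 1.1-fold higher number from compound 1 to compound 2 (0.06 log units; within the scatter) is within the scatter, so the two compounds cannot be ordered. That step is a change of substituent, nitro in place of fluoro on an aromatic carbon, and it does not involve the double bond.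

Compound 3, `CC(=O)OC/C(=C/c1ccccc1[N+](=O)[O-])C(=O)c1ccccc1`, has not yet been measured in this assay. Its difference from compound 2 is the two compounds have the same atoms and bonds and differ only in configuration as drawn: 1 of 1 stereo elements differ; a double bond is drawn E in compound 2 and Z in compound 3. Going by the values given here, no measured pair in this small set separates the two configurations of that double bond, so no step bears on the change directly, and there is no basis to assign a direction. Among the compounds with values here, only the size of the one measured step, within the scatter, hints at how little the series has moved so far.

Compound 3 is therefore expected to give a number close to that of compound 2, the step being estimated as no change at the digits printed from compound 2 to compound 3 (within the scatter), with a wide range to reflect the lack of any precedent for this kind of change. The estimate for compound 3 in this assay is 25000 nM, between 8000 nM and 80000 nM.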

Compound 3, concentration for 50% growth inhibition: 78000 nM
The estimate for compound 3 lay 3.1-fold (0.49 log units) below the measured number; low and high end bracket the measured number.
By their numbers in this assay, from the lowest: compounds 1 and 2 (each within the scatter of the next); then compound 3.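

In this assay, going by these compounds alone, the double bond is the first place where a change moves the number beyond the scatter: the series shows a 3.1-fold higher number from compound 2 to compound 3 (0.49 log units; beyond the scatter), a modest step, while the earlier substituent exchange gave a 1.1-fold higher number from compound 1 to compound 2 (0.06 log units; within the scatter). With the nitro group held constant, the Z form as drawn therefore gives weaker growth inhibition than the E form, so configuration at this double bond counts for more here than the exchange of fluoro for nitro on the aromatic carbon. The step can be assigned to configuration alone, because no atom or bond changes between the pair: the fact that compounds 2 and 3 differ only in the configuration as drawn.

Among the compounds shown, the Z form appears only with the nitro group, so whether a fluoro compound would show a similar step remains open, and a single pair sets no rule for the series. Also open, as far as these compounds go, is how the number would respond if a free alcohol or an amine took the place of the acetate ester, or if a methoxy group or a carboxylic acid stood on the aromatic ring instead of nitro or fluoro.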